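This account rests on a few compounds, and the source may have more. Where it says the series, first, only, none or still open, it means among the compounds named here.

Three close relatives of one core have been measured in a physicochemical assay for solubility, in phosphate buffer, at pH 7.4; on this read-out higher numbers stand for higher solubility and lower numbers for lower solubility. Compound 1, `CNC(=O)CN1CCC(c2cc3c(-c4ccc(=O)n(C(C)C)c4)ccnc3[nH]2)CC1`, gives 34000 nM in this assay. Compound 2, `CC(C)n1cc(-c2ccnc3[nH]c(C4CCN(CC(=O)N5CCCC5)CC4)cc23)ccc1=O`, gives 260000 nM, and compound 3, `CN(C)C(=O)CN1CCC(c2cc3c(-c4ccc(=O)n(C5CCOCC5)c4)ccnc3[nH]2)CC1`, gives 840000 nM. Compound 1 therefore stands lowest of the three: the nearest number is that of compound 2, and the furthest is that of compound 3, which differs from compound 1 in two places at once, so its value can only be set beside that of compound 1 without being read as a single step.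

The compound now to be measured is compound 4, `CC(C)n1cc(-c2ccnc3[nH]c(C4CCN(CC(=O)N(C)C)CC4)cc23)ccc1=O`. It differs from compound 1 by methyl in place of hydrogen on an amide-type nitrogen. For the measured compounds named here, the one measured step that bears on this is a 7.6-fold higher number from compound 1 to compound 2 (0.88 log units; beyond the scatter), where the same amide-type nitrogen lost its hydrogen by being folded into a ring. A step of similar size and direction is expected here, namely a 5.9-fold higher number from compound 1 to compound 4 (0.77 log units; beyond the scatter). Compound 4 is accordingly estimated at 200000 nM, with a likely range from 60000 nM to 600000 nM.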

Compound 4, solubility: 110000 nM
Beside the measured number, compound 4's estimate is 1.8-fold (0.26 log units) above it, and the stated range covers the measured number.
By their numbers in this assay, from the lowest: compound 1; then compound 4; then compound 2; then compound 3.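

In this assay methyl in place of hydrogen on the amide-type nitrogen, with no ring formed, gives a 3.2-fold higher number from compound 1 to compound 4 (0.51 log units; beyond the scatter) and thus shows that this single change raises the number without the ring of compound 2. The ring still matters, since dimethylamino in place of pyrrolidin-1-yl on the carbonyl carbon gives a 2.4-fold lower number from compound 2 to compound 4 (0.37 log units; beyond the scatter) and so the two amides lacking that hydrogen do not read alike. For the compounds shown here, with the dimethylamino amide held constant, isopropyl in place of oxan-4-yl on the aromatic nitrogen gives a 7.6-fold lower number from compound 3 to compound 4 (0.88 log units; beyond the scatter) as the first single-place reading of that second site.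

No evidence at hand explains any of these steps. Still open, on these data alone, is how this amide would read with a morpholine ring or a diethylamino group on the carbonyl carbon.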